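A few compounds are considered here, and "the series" means these few. Any claim that something is new, unique, unknown or untested is made for them only; others in the source may bear on it.

In a functional assay (aorta) for inhibition, with Rattus norvegicus as the target (on this read-out higher numbers stand for weaker inhibition and lower numbers for stronger inhibition), compound 1 `CC/N=C(\S)[C@]1(c2cccnc2)CCCC[S+]1[O-]` gives 300 nM. Compound 2 `N#C[C@]1(c2cccnc2)CCCC[S+]1[O-]` gives > 30000 nM, which is only a limit. Compound 3 `CNC(=O)[C@]1(c2cccnc2)CCCC[S+]1[O-]` gives > 30000 nM, and this too is only a limit, so compound 3 has no exact position on the scale. Its step from the nitrile is correspondingly uninformative: a step that the two limits leave unreadable from compound 2 to compound 3.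

Compound 4 `C/N=C(\SC)[C@]1(c2cccnc2)CCCC[S+]1[O-]` is reached from compound 3 by this change: a group of 5 heavy atoms (3 carbon, 1 nitrogen, 1 sulfur; no ring) in place of a group of 4 heavy atoms (2 carbon, 1 nitrogen, 1 oxygen; no ring), on a saturated ring carbon. The methylcarbamoyl leaves, and a group of 5 heavy atoms (3 carbon, 1 nitrogen, 1 sulfur; no ring) enters. Compound 1 carries a group with the same count, although the two groups are not identical.

Among the measured compounds shown here, two measured steps bear on this change, and both are large: an at least 100-fold higher number from compound 1 to compound 2 (2.00 log units; beyond the scatter) and an at least 100-fold higher number from compound 1 to compound 3 (2.00 log units; beyond the scatter). Reversing the second of these suggests a gain, but only a partial one is expected, since the entering group differs from that of compound 1. The expected change in this assay is an at least 6.0-fold lower number from compound 3 to compound 4 (0.77 log units; beyond the scatter), towards stronger inhibition. Compound 4 is estimated at 5000 nM, with an expected range from 600 nM to 30000 nM.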

Compound 4, concentration for 90% inhibition: > 30000 nM
Compound 4: no number, only a limit; the forecaster's own chance of this, stated with the estimate: 40%; middle value at least 6.0-fold (0.77 log units) away from the limit.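

Compound 4 shows that matching the heavy-atom count of the group in compound 1 on this saturated ring carbon does not by itself restore inhibition: this assay records an at least 100-fold higher number from compound 1 to compound 4 (2.00 log units; beyond the scatter). Among these compounds, the count alone therefore does not carry the inhibition seen with compound 1, and the arrangement of the atoms within the group matters. The steps to compound 4 from compound 2 and from compound 3 cannot be read, because all three compounds sit at the same limit: the limit of > 30000 nM in this assay, at which 3 of the 4 values shown sit.

Going by these compounds, how far compounds 2, 3 and 4 lie beyond that limit stays open. So does the question of which difference between the groups of compound 1 and compound 4 counts, and a group with a propyl chain on the nitrogen, or an amine on this carbon, is not among those shown.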